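This account rests on a few compounds, and the source may have more. Where it says the series, first, only, none or still open, it means among the compounds named here.

The three compounds measured in a functional assay on HepG2 cells (Homo sapiens) for positive allosteric modulation, tested at 25 uM (on this read-out lower numbers stand for a weaker effect and higher numbers for a stronger effect at the one concentration tested), are:

compound 1 `NC1=NN(c2ccccc2)C(=O)/C1=C/Nc1ccc(S(=O)(=O)Nc2ccccn2)cc1` with 76.7%
compound 2 `Cc1cc(C)nc(NS(=O)(=O)c2ccc(N/C=C3/C(=N)N(c4ccccc4)N=C3N)cc2)n1` with 92.9%
compound 3 `N=C1NN=C(N)/C1=C\Nc1ccc(S(=O)(=O)Nc2cnc3ccccc3n2)cc1` with 80.6%

Compound 1 sits at the lower end of these three numbers. Its nearest neighbour is compound 3, whose reading lies within the usual scatter of that of compound 1, so the two cannot be told apart; compound 2 lies beyond the scatter above compound 1 and is the only one of the three that clearly separates from it.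

Compound 4 `NC1=NN(c2ccccc2)C(=O)/C1=C/Nc1ccc(S(=O)(=O)Nc2cnc3ccccc3n2)cc1` has not yet been measured in this assay. It is compound 1 with one change, (quinoxalin-2-yl in place of pyridin-2-yl on a sulfonamide nitrogen). Among the compounds with values here, no pair of measured compounds shows this change on an otherwise identical structure, so its size must be judged from what is at hand: compound 3 carries the same quinoxalin-2-yl group on a different core and gives 80.6%, which is within the scatter of compound 1. On that basis the step from compound 1 to compound 4 is expected to be small, if anything slightly upward, and probably not beyond the scatter; the estimated step is a number 3.3 percentage points higher from compound 1 to compound 4 (within the scatter). For compound 4 the estimate in this assay is therefore 80%, with a likely range from 68% to 92%.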

Compound 4, a percentage reported as activity, at one concentration (the size of the read-out at that concentration, not a potency): 93.5%
The estimate for compound 4 lay 13.5 percentage points below the measured number; the measured number lies above the stated range.
By their numbers in this assay, from the lowest: compounds 1 and 3 (each within the scatter of the next); then compounds 2 and 4 (each within the scatter of the next).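

In this assay the exchange of pyridin-2-yl for quinoxalin-2-yl on a sulfonamide nitrogen, with the rest of the core of compound 1 unchanged, gives a number 16.8 percentage points higher from compound 1 to compound 4 (beyond the scatter) and so provides the one direct reading of this change among the compounds shown. The position on the sulfonamide nitrogen is therefore sensitive to the group it carries, at least on this core, where the entering group brings 10 heavy atoms in place of 6 and includes one six-membered aromatic ring of carbon only. Nothing at hand accounts for the size of this step.

Within the data shown here, the single pair does not separate the contribution of the ring of carbon from that of the extra ring nitrogen, so what quinolin-2-yl or pyrazin-2-yl would give on the same sulfonamide nitrogen remains open. Also open is whether the change carries over to the core of compound 3, since no compound shown has pyridin-2-yl on that core, and whether the stronger effect seen at this one concentration would also be seen at other concentrations.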